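The compounds below may be only part of what the source reports. "The series", "measured", "known", "first", "only" and "open" are said of these compounds alone.

Values in a functional assay on MCF7 cells (Homo sapiens) for inhibition, read by CCK-8 assay, with a stated time of 48 h; on this read-out higher numbers stand for weaker inhibition and lower numbers for stronger inhibition:
- compound 1 `COc1cc(-c2ccnc3cc(-c4c[nH]c5ccccc45)nn23)cc(OC)c1OC`: 85 nM
- compound 2 `COc1cc(-c2ccnc3cc(-c4ccc(C)c(C)c4)nn23)cc(OC)c1OC`: 26 nM
- compound 3 `COc1cc(-c2ccnc3cc(-c4cccc(C#N)c4)nn23)cc(OC)c1OC`: > 10000 nM (a limit, not a number)

Not yet measured: compound 4 `COc1cc(-c2ccnc3cc(-c4ccc(C(F)(F)F)cc4)nn23)cc(OC)c1OC`.

Compound 3 stands only as a limit, and the series holds a single such case: the limit of > 10000 nM in this assay, at which 1 of the 3 values shown sits.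

The next change puts 4-(trifluoromethyl)phenyl in place of 3-cyanophenyl on an aromatic carbon of the shared core (4-(trifluoromethyl)phenyl in place of 3-cyanophenyl on an aromatic carbon). The steps into 3-cyanophenyl bear most directly on this change: an at least 110-fold higher number from compound 1 to compound 3 (2.07 log units; beyond the scatter) and an at least 380-fold higher number from compound 2 to compound 3 (2.58 log units; beyond the scatter). Both are large. The step between the two groups that retain activity is only modest: a 3.3-fold lower number from compound 1 to compound 2 (0.51 log units; beyond the scatter).

Taken in reverse, the steps into compound 3 lead to the expectation of a large step to a lower number in this assay once 3-cyanophenyl leaves. Its true size cannot be fixed, since one end is a limit. Going by the values given here, the entering group has no measured precedent on this core, so a full return to the level of compound 2 at 26 nM is not assumed, and the expected range stays wide.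

The estimated move is an at least 33-fold lower number from compound 3 to compound 4 (1.52 log units; beyond the scatter). For compound 4 the expected value is 300 nM, with an estimated range from 40 nM to 5000 nM.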

Compound 4, half-maximal inhibitory concentration: 2440 nM
Compound 4: the middle estimate sits 8.1-fold (0.91 log units) below what was measured; measured number inside the range.
By their numbers in this assay, from the lowest: compound 2; then compound 1; then compound 4. At a limit, above all of these: compound 3.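

In this assay, 4-(trifluoromethyl)phenyl on this aromatic carbon of the shared core gives a measurable value where 3-cyanophenyl gave only a limit, with an at least 4.0-fold lower number from compound 3 to compound 4 (0.61 log units; beyond the scatter). That step is a minimum, and its upper end is not known, as compound 3 stands only at a limit: the limit of > 10000 nM in this assay, at which 1 of the 4 values shown sits.

Compound 4 still falls far short of the two groups that retain activity, with a 94-fold higher number from compound 2 to compound 4 (1.97 log units; beyond the scatter) and a 29-fold higher number from compound 1 to compound 4 (1.46 log units; beyond the scatter), so the position now shows a graded order among its groups, not a simple split between three active groups and one inactive one.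

3-Cyanophenyl and 4-(trifluoromethyl)phenyl differ in both the substituent and where it sits on the phenyl ring, so the compounds shown cannot assign the gap between compound 3 and compound 4 to either difference. A 4-cyanophenyl or 3-(trifluoromethyl)phenyl group would separate the two, while a 4-methylphenyl or 3-methylphenyl group would show whether both methyl groups of compound 2 are needed for its value.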